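The source may report more compounds than this note shows. Statements on the series, on what has been measured and on what is new or still open speak of the compounds shown alone.

Series notes. Compound 1 `CC(C(=O)NCc1ccc(C(F)(F)F)nc1Cl)c1ccc(NS(C)(=O)=O)c(F)c1` gives 0.2 nM in an assay on CHO cells for antagonist activity at transient receptor potential cation channel subfamily V member 1 (Homo sapiens), read by FLIPR and calcium flux; on this read-out higher numbers stand for weaker inhibition and lower numbers for stronger inhibition. Compound 2 `Cc1nc(C(F)(F)F)ccc1CNC(=O)C(C)c1ccc(NS(C)(=O)=O)c(F)c1` gives 387 nM, and compound 3 `CC(C(=O)NCc1ccc(C(F)(F)F)nc1CCC(C)(C)C)c1ccc(NS(C)(=O)=O)c(F)c1` gives 0.6 nM in this assay. Compound 3 therefore holds the second highest of the three numbers, standing nearer to compound 1 than to compound 2. Compound 4 `CC(C(=O)NCc1ccc(C(F)(F)F)nc1C1=CCCCC1)c1ccc(NS(C)(=O)=O)c(F)c1` carries the change (cyclohex-1-en-1-yl in place of 3,3-dimethylbutyl on an aromatic carbon). Among the measured compounds shown here, three measured steps touch this position: a 1900-fold higher number from compound 1 to compound 2 (3.29 log units; beyond the scatter) was large, a 3.0-fold higher number from compound 1 to compound 3 (0.48 log units; beyond the scatter) was modest, and a 650-fold lower number from compound 2 to compound 3 (2.81 log units; beyond the scatter) was large. The leaving group and the entering group are alike in size at a position where a large group was already tolerated, so the expected step of no change at the digits printed from compound 3 to compound 4 (within the scatter) is small, within or close to the scatter. Compound 4 is estimated at 0.6 nM, with a range of 0.15 nM to 3 nM.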

Compound 4, inhibition constant: 0.7 nM
Estimate against measurement, compound 4: 1.2-fold (0.07 log units) below; measured number inside the range.
By their numbers in this assay, from the lowest: compound 1; then compounds 3 and 4 (each within the scatter of the next); then compound 2.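

In this assay, a ring with a double bond reads the same as the open chain of equal heavy-atom count (a 1.2-fold higher number from compound 3 to compound 4 (0.07 log units; within the scatter)), so this position accepts cyclic and acyclic groups alike in these two compounds. Cyclohex-1-en-1-yl also keeps the large drop in number from methyl (a 550-fold lower number from compound 2 to compound 4 (2.74 log units; beyond the scatter)), yet, like 3,3-dimethylbutyl, it does not match chloro (a 3.5-fold higher number from compound 1 to compound 4 (0.54 log units; beyond the scatter)). No measurement here gives a cause for any of these steps.

Going by these compounds, whether a saturated cyclohexyl ring, a phenyl ring or an amine at this position would read the same remains open.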